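The compounds below may be only part of what the source reports. "The series", "measured", "known", "first", "only" and "open" are said of these compounds alone.

Measured so far in an assay on isolated protein for displacement of a labelled ligand from metabotropic glutamate receptor 5 (Homo sapiens), with a stated time of 60 min, tested at 1 uM; a lower number here means less inhibition, a higher number more inhibition at the concentration tested (going by the name of the read-out):
compound 1 `COc1ccc2ncc(S(=O)(=O)c3ccc(Cl)cc3)c(N3CCC(C)CC3)c2c1` — 91%
compound 2 `COc1ccc2ncc(S(=O)(=O)c3ccc(Cl)c(Cl)c3)c(N3CCC(C)CC3)c2c1` — 87%
compound 3 `COc1ccc2ncc(S(=O)(=O)c3cccc(C#N)c3)c(N3CCC(C)CC3)c2c1` — 90%

Compound 3 stands second highest of the three, but every gap is within the scatter: a number 1 percentage points lower from compound 1 to compound 3 (within the scatter) and a number 3 percentage points higher from compound 2 to compound 3 (within the scatter). Compound 4 `COc1ccc2ncc(S(=O)(=O)c3cccc(Cl)c3)c(N3CCC(C)CC3)c2c1` is the next compound, differing from compound 3 by chloro in place of cyano on an aromatic carbon. For the measured compounds named here, the steps that bear on it are the chloro addition in a number 4 percentage points lower from compound 1 to compound 2 (within the scatter) and the two aryl swaps on the sulfonyl sulfur, all within the scatter; no measured step exchanges cyano for chloro directly. A step beyond the scatter is therefore not expected, and the expected step is a number 1 percentage points lower from compound 3 to compound 4 (within the scatter). Compound 4 is estimated at 89%, with a range from 80% to 95%.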

Compound 4, a percentage reported as inhibition, at one concentration (the size of the read-out at that concentration, not a potency): -3%
For compound 4 the middle estimate is 92 percentage points above the measured one, and the stated range ends above it.
By their numbers in this assay, from the lowest: compound 4; then compounds 2, 3 and 1 (each within the scatter of the next).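

In this assay there is a number 93 percentage points lower from compound 3 to compound 4 (beyond the scatter) when the cyano group gives way to chloro, so the position that bears it, unremarkable across compound 1, compound 2 and compound 3, proves highly sensitive to the group it carries. There is also a number 94 percentage points lower from compound 1 to compound 4 (beyond the scatter) for 3-chlorophenyl in place of 4-chlorophenyl and a number 90 percentage points lower from compound 2 to compound 4 (beyond the scatter) for hydrogen in place of chloro, so 3-chlorophenyl loses the inhibition that 4-chlorophenyl and 3,4-dichlorophenyl retain. Nothing at hand accounts for this loss.

As far as these compounds go, whether a phenyl carrying methoxy or fluoro at this place, or an unsubstituted phenyl, would follow compound 3 or compound 4 remains open.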